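Urea in place of amide on a pyrazole scaffold

The compounds below may be only part of what the source reports. "The series", "measured", "known", "first", "only" and "open" are said of these compounds alone.

This account follows one change on a shared core. In a functional assay on HCT-116 cells (Homo sapiens) for inhibition, read by sulforhodamine B assay, with a stated time of 48 h (on this read-out higher numbers stand for weaker inhibition of growth and lower numbers for stronger inhibition of growth), compound 1 `COc1cc(-c2nn(-c3cccc(NC(=O)c4ccc(Cl)c(C(F)(F)F)c4)c3)cc2-c2ccncc2)ccc1Cl` gives only a limit of the assay, > 32500 nM, so where it stands among the numbers is not known beyond (the limit of > 32500 nM in this assay, at which 1 of the 2 values shown sits). Compound 2 `O=C(Nc1cccc(-n2cc(-c3ccncc3)c(-c3ccc(Cl)c(O)c3)n2)c1)Nc1cccc(C(F)(F)F)c1`, which carries a urea on a related core, gives 8260 nM in this assay. The unmeasured compound 3 `COc1cc(-c2nn(-c3cccc(NC(=O)Nc4ccc(Cl)c(Cl)c4)c3)cc2-c2ccncc2)ccc1Cl` differs from compound 1 by (3,4-dichlorophenyl)amino in place of 4-chloro-3-(trifluoromethyl)phenyl on a carbonyl carbon. Because compound 2 reaches 8260 nM with a urea, a step from compound 1 toward stronger growth inhibition is expected, of a size that the measured data do not fix. Compound 3 is thus expected to give 15000 nM in this assay, within the range 4000 nM to 60000 nM, which would mean an expected step of an at least 2.1-fold lower number from compound 1 to compound 3 (0.33 log units; beyond the scatter).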

Compound 3, concentration for total growth inhibition: > 50000 nM
Compound 3 was reported as a limit; the forecaster's own chance of this, stated with the estimate: 40%; middle value at least 3.3-fold (0.52 log units) away from the limit.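

In this assay, within the data shown here, compound 1 and compound 3 are both reported only as limits, and no step between them can be read. The compounds shown leave open whether (3,4-dichlorophenyl)amino in place of 4-chloro-3-(trifluoromethyl)phenyl on the carbonyl carbon changes growth inhibition at all.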